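The source may report more compounds than this note shows. Statements on the series, on what has been measured and on what is new or still open speak of the compounds shown alone.

Measured so far:
compound 1 `COc1cc(N2CCN(C(=O)C3CCC(O)CC3)CC2)ccc1Nc1nc(NC2CCCCC2)c2nc[nH]c2n1` — 81 10^-6 cm/s
compound 2 `COc1cc(N2CCN(Cc3ccccn3)CC2)ccc1Nc1nc(NC2CCCCC2)c2nc[nH]c2n1` — 976 10^-6 cm/s

In an ADME assay for permeability, using PAMPA (on this read-out lower numbers stand for lower permeability and higher numbers for higher permeability), compound 2 stands highest of the two numbers shown, with compound 1 well below it. Compound 3 `COc1cc(N2CCN(CC3CCOC3)CC2)ccc1Nc1nc(NC2CCCCC2)c2nc[nH]c2n1` has not been measured yet. It differs from compound 2 in one place: oxolan-3-yl in place of pyridin-2-yl on a saturated chain carbon bound to an amine nitrogen in a ring. Among the measured compounds shown here, the only measured step, a 12-fold higher number from compound 1 to compound 2 (1.08 log units; beyond the scatter), swaps a different group on the same amine nitrogen in a ring, so it bears only loosely on this change. A step within the scatter, leaning slightly downward, is therefore expected: a 1.4-fold lower number from compound 2 to compound 3 (0.14 log units; within the scatter). For compound 3 the estimate is 700 10^-6 cm/s, with a range from 300 10^-6 cm/s to 1300 10^-6 cm/s.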

Compound 3, apparent permeability: 1870 10^-6 cm/s
Compound 3: middle estimate off by 2.7-fold (0.43 log units), on the low side; measured number above the stated range.
By their numbers in this assay, from the lowest: compound 1; then compounds 2 and 3 (each within the scatter of the next).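

In this assay, the non-aromatic oxolan-3-yl ring and the aromatic pyridin-2-yl ring on this saturated chain carbon cannot be told apart (a 1.9-fold higher number from compound 2 to compound 3 (0.28 log units; within the scatter)). An aromatic ring is therefore not needed here to hold the number, and (oxolan-3-yl)methyl also keeps a large gap to the (4-hydroxycyclohexyl)carbonyl group (a 23-fold higher number from compound 1 to compound 3 (1.36 log units; beyond the scatter)). No measurement shown explains either step. Still open, from the compounds shown here alone, is how an amine or a carboxylic acid on this chain carbon would read, and whether a longer chain to the ring would change the number.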